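Swapping the difluoromethyl for methyl on compound 1

The compounds below may be only part of what the source reports. "The series", "measured", "known", "first", "only" and "open" are said of these compounds alone.

Measured compounds:
- compound 1, `COc1cc(CS(=O)(=O)c2nc3cc(OC(F)F)ccc3[nH]2)ccc1OCc1ncc(C)c(OC)c1C`: 1420 nM
- compound 2, `COCCCOc1ccnc(COc2ccc(CS(=O)(=O)c3nc4ccccc4[nH]3)cc2OC)c1C`: 355 nM
- compound 3, `COc1cc(CS(=O)(=O)c2nc3ccccc3[nH]2)ccc1OCc1nccc(OC)c1OC`: 212 nM

In a functional assay on cells (Erythrocyte, Homo sapiens) (on this read-out higher numbers stand for weaker inhibition and lower numbers for stronger inhibition), compound 1 gives 1420 nM, the highest number among the three measured compounds. Compound 2 gives 355 nM and compound 3 gives 212 nM, both lower than compound 1 by margins beyond the scatter, so compound 1 is the weakest inhibitor of the three.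

Compound 4, `COc1ccc2[nH]c(S(=O)(=O)Cc3ccc(OCc4ncc(C)c(OC)c4C)c(OC)c3)nc2c1`, is not yet measured. It differs from compound 1 in one place: methyl in place of difluoromethyl on an oxygen on an aromatic ring. Among the measured compounds shown here, no pair of measured compounds shows this same change, so the size of the step must be expected rather than read off. Because compound 1 stands at 1420 nM while compounds 2 and 3, which carry the same shared core, sit lower, an improvement is considered plausible but uncertain. The step from compound 1 to compound 4 is expected to be a 2.0-fold lower number from compound 1 to compound 4 (0.31 log units; beyond the scatter) in this assay. Compound 4 is expected to give 700 nM, with a range from 250 nM to 2500 nM.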

Compound 4, half-maximal inhibitory concentration: 1210 nM
For compound 4 the middle estimate is 1.7-fold (0.24 log units) below the measured one; the range from low to high includes it.
By their numbers in this assay, from the lowest: compounds 3 and 2 (each within the scatter of the next); then compounds 4 and 1 (each within the scatter of the next).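

In this assay, among the compounds shown here, the swap of difluoromethyl for methyl on an oxygen on an aromatic ring gives a 1.2-fold lower number from compound 1 to compound 4 (0.07 log units; within the scatter) and provides the first direct reading of a change at this place. On the shared core of these two compounds, difluoromethoxy and methoxy cannot be told apart on this read-out. No measured evidence bears on the reason for this result.

Compounds 2 and 3 differ from compound 1 in more than one place, and their lower numbers cannot be assigned to any single change. Also open, as far as these compounds go, is whether a different group on this oxygen, such as trifluoromethyl or a longer chain like propyl, or an amine in place of the whole methoxy group, would shift the number beyond the scatter.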